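Dropping one fluoro from compound 2

A few compounds are considered here, and "the series" means these few. Any claim that something is new, unique, unknown or untested is made for them only; others in the source may bear on it.

In a functional assay on T-24 cells (Homo sapiens) for antiproliferative activity, read by MTT assay, with a stated time of 72 h (a higher number here means a weaker inhibitor, a lower number a stronger inhibitor), compound 1 (`CC(C)NC(=N)NC(=N)Nc1ccc(C(F)(F)F)cc1`) gives 4800 nM and compound 2 (`CC(C)NC(=N)NC(=N)Nc1ccc(F)c(F)c1`) gives 45000 nM as the higher of the two numbers, a gap beyond the scatter. The change to compound 3 (`CC(C)NC(=N)NC(=N)Nc1ccc(F)cc1`) is hydrogen in place of fluoro on an aromatic carbon with hydrogen in place of fluoro on an aromatic carbon. Within the data shown here, no measured pair shows this change alone, so only a small step is expected in this assay toward a higher number, possibly none beyond the scatter. The estimated step is a 1.2-fold higher number from compound 2 to compound 3 (0.09 log units; within the scatter) and remains an expectation. Compound 3 is expected at 55000 nM within an estimated range of 22000 nM to 130000 nM for now.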

Compound 3, half-maximal inhibitory concentration: > 50000 nM
Compound 3: a limit, no number; the forecaster's own chance of this, stated with the estimate: 15%; the middle value lies beyond the limit too.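

In this assay compound 3 gives a limit, not a number: the limit of > 50000 nM in this assay, at which 1 of the 3 values shown sits. Hydrogen in place of fluoro on this aromatic carbon brings no gain, with an at least 1.1-fold higher number from compound 2 to compound 3 (0.04 log units; that floor lies within the scatter), so the true size of this step stays unread. Fluoro in place of trifluoromethyl on an aromatic carbon gives an at least 10-fold higher number from compound 1 to compound 3 (1.01 log units; beyond the scatter), the first single-place change in the series with a step beyond the scatter, and it favours the trifluoromethyl compound.

Still open, going by these compounds, is whether a nitrile, a methoxy group or an amine in place of trifluoromethyl would keep the number of compound 1 (4800 nM). On these data alone, the distance between compound 2 and compound 3 also remains open.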